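Moving the Methoxy Group: Compound 2 to Compound 4

A few compounds are considered here, and "the series" means these few. Any claim that something is new, unique, unknown or untested is made for them only; others in the source may bear on it.

Compound 2 `Cc1ccc(Nc2cc(C)nc(SCc3nc4ccccc4[nH]3)n2)cc1` is one of three close analogues built on a shared core. In a functional assay on ECa-109 cells (Homo sapiens) for cytotoxicity, read by MTT assay, with a stated time of 72 h (a higher number here means a weaker inhibitor, a lower number a stronger inhibitor), compound 2 gives 57300 nM, the lower of the two numbers reported. Compound 1 `COc1ccc(Nc2cc(C)nc(SCc3nc4ccccc4[nH]3)n2)cc1` gives 69800 nM in this assay, and the step of a 1.2-fold lower number from compound 1 to compound 2 (0.09 log units; within the scatter) shows that the two numbers sit within the scatter. For compound 3 `Cc1cc(N2CCNCC2)nc(SCc2nc3ccccc3[nH]2)n1` this assay reports a limit, > 100000 nM, and no number. Compound 4 `COc1ccccc1Nc1cc(C)nc(SCc2nc3ccccc3[nH]2)n1` has not been measured; its change from compound 2 is 2-methoxyphenyl in place of 4-methylphenyl on a nitrogen on an aromatic ring. Among the measured compounds shown here, the only measured step that bears on it is a 1.2-fold lower number from compound 1 to compound 2 (0.09 log units; within the scatter), which exchanges methyl and methoxy and lies within the scatter, so no change beyond the scatter is expected from compound 2 to compound 4 in this assay. Compound 4 is estimated at 65000 nM, between 30000 nM and 100000 nM. The expected step is a 1.1-fold higher number from compound 2 to compound 4 (0.05 log units; within the scatter).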

Compound 4, half-maximal inhibitory concentration: 34400 nM
Estimate against measurement, compound 4: 1.9-fold (0.28 log units) above, and the stated range covers the measured number.
By their numbers in this assay, from the lowest: compounds 4, 2 and 1 (each within the scatter of the next, the first and the last beyond it). At a limit, above all of these: compound 3.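

In this assay, among the compounds shown here, 2-methoxyphenyl in place of 4-methoxyphenyl gives a 2.0-fold lower number from compound 1 to compound 4 (0.31 log units; beyond the scatter) and is the first step between two measured numbers to clear the scatter, so moving the methoxy group on this ring can register. Against 4-methylphenyl, the same group gives a 1.7-fold lower number from compound 2 to compound 4 (0.22 log units; within the scatter) and does not separate the two compounds. Compound 3 stands at a limit, and (2-methoxyphenyl)amino in place of its piperazin-1-yl gives an at least 2.9-fold lower number from compound 3 to compound 4 (0.46 log units; beyond the scatter), a step that rests on that limit: the limit of > 100000 nM in this assay, at which 1 of the 4 values shown sits.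

The compounds shown leave open how an amine or a carboxylic acid in place of the methoxy group would read on this ring. They also leave open whether a longer chain on its oxygen would keep the step.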